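A few compounds are considered here, and "the series" means these few. Any claim that something is new, unique, unknown or untested is made for them only; others in the source may bear on it.

Measured so far:
Compound 1, `O=C(Nc1cccc(-c2ccc(CO)cc2)c1)c1ccccc1`. In an assay for binding affinity to 17-beta-hydroxysteroid dehydrogenase type 1 (Homo sapiens), with a stated time of 20 min, tested at 1 uM (on this read-out lower numbers stand for less inhibition and higher numbers for more inhibition at the one concentration tested (going by the name of the read-out)), compound 1 gives < 10%, which is a limit of the assay rather than a number.
Compound 2, `CN(C(=O)c1ccccc1)c1cccc(-c2ccc(CO)cc2)c1`. In this assay compound 2 gives < 10%, again a limit of the assay.
Compound 3, `COc1ccc(C(=O)N(C)c2cccc(-c3ccc(CO)cc3)c2)cc1`. In this assay compound 3 gives < 10%, also a limit of the assay.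

Compound 3 therefore stands at the limit, and the two further values shown for this series are limits as well, so no ranking among the three can be read. The compound that follows is compound 4, `COc1ccc(C(=O)N(C)c2cccc(-c3ccc(OC)cc3)c2)cc1`; its difference from compound 3 is methoxy in place of hydroxymethyl on an aromatic carbon. Two measured steps exist in the series: a step that the two limits leave unreadable from compound 1 to compound 2 and a step that the two limits leave unreadable from compound 2 to compound 3. Neither has a readable size because of the limit of < 10% in this assay, at which 3 of the 3 values shown sit. For the measured compounds named here, no measured step speaks to swapping a hydroxymethyl for a methoxy, so nothing points to a step beyond the scatter in either direction. Compound 4 is expected to stay at the limit, estimated at 5% with a range from 0% to 15%. The step this estimate implies is a step that the limit leaves unreadable from compound 3 to compound 4, expected to be within the scatter.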

Compound 4, a percentage reported as inhibition, at one concentration (the size of the read-out at that concentration, not a potency): < 10%
Compound 4: only a limit was reported (the forecaster's own chance of this, stated with the estimate: 80%); the middle value lies beyond the limit too.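

The step from hydroxymethyl to methoxy between compound 3 and compound 4 cannot be read, because both compounds sit at a limit of the assay rather than at a number: the limit of < 10% in this assay, at which 4 of the 4 values shown sit.

The compounds shown leave open how these four rank against one another in this assay, and which change to the shared core, if any, would give a readable inhibition there.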